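Swapping propylamino for a methylpiperidine in compound 1

A few compounds are considered here, and "the series" means these few. Any claim that something is new, unique, unknown or untested is made for them only; others in the source may bear on it.

compound 1 `CCCNc1nc(C(C)c2c(F)cccc2F)c(C)c(=O)[nH]1`: 35000 nM
compound 2 `O=c1cc(Cc2c(F)cccc2F)nc(N2CCCCC2)[nH]1`: > 82000 nM (a limit)
compound 3 `CC1CCCN(c2nc(Cc3c(F)cccc3F)cc(=O)[nH]2)C1`: > 78000 nM (a limit)

Among the compounds with values here, in an ADME assay on MT4 cells (Homo sapiens) for cytotoxicity, read by MTT assay, with a stated time of 4 days (on this read-out higher numbers stand for lower toxicity in this test and lower numbers for higher toxicity in this test), compound 1 gives 35000 nM, the only true number among the three. The entries for compound 2 and compound 3 are limits of the assay. Compound 4 `Cc1c(C(C)c2c(F)cccc2F)nc(N2CCCC(C)C2)[nH]c1=O` is still unmeasured, and it differs from compound 1 in one place: 3-methylpiperidin-1-yl in place of propylamino on an aromatic carbon. Within the data shown here, the one measured step that bears on this is a step that the two limits leave unreadable from compound 2 to compound 3, with methyl in place of hydrogen on a saturated ring carbon. Compound 3 holds the 3-methylpiperidin-1-yl group on a different core and stays at the limit > 78000 nM. A small move toward lower toxicity in this assay, within the usual scatter, is therefore expected, estimated as a 1.4-fold higher number from compound 1 to compound 4 (0.15 log units; within the scatter). Compound 4 is expected at 50000 nM, with an estimated range from 20000 nM to 110000 nM.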

Compound 4, half-maximal cytotoxic concentration: > 72000 nM
Compound 4 ended at the assay's limit (the forecaster's own chance of this, stated with the estimate: 35%); middle value at least 1.4-fold (0.15 log units) from the limit.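

In this assay, 3-methylpiperidin-1-yl in place of propylamino, on the aromatic carbon between two ring nitrogen atoms, gives an at least 2.0-fold higher number from compound 1 to compound 4 (0.31 log units; beyond the scatter). Within the data shown here, this is the first readable step at this position, since the step between compound 2 and compound 3 cannot be read. Its full size stays unknown, because compound 4 sits at a limit of the assay: the limit of > 72000 nM in this assay, at which 1 of the 4 values shown sits.

Going by these compounds, whether the ring alone or its methyl goes with this change remains open on this core. So does the outcome with morpholin-4-yl or a longer chain such as pentylamino at this position.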